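From Hydroxy to Diethylamino on Compound 2

This account rests on a few compounds, and the source may have more. Where it says the series, first, only, none or still open, it means among the compounds named here.

In a functional assay on MCF7 cells (Homo sapiens) for cytotoxicity, read by MTT assay, with a stated time of 72 h (a higher number here means a weaker inhibitor, a lower number a stronger inhibitor), compound 1 `COc1cc2ncnc(Nc3ccc(F)c(Cl)c3)c2cc1NC(=O)N/N=C/c1cccc(Br)c1` gives 27100 nM, and compound 2 `COc1cc2ncnc(Nc3ccc(F)c(Cl)c3)c2cc1NC(=O)N/N=C/c1ccc(O)cc1O` gives 36200 nM. Within the data shown here, these are the only two measurements, and they lie within the scatter of each other, so compound 2 cannot be separated from compound 1. Compound 3 `CCN(CC)c1ccc(/C=N/NC(=O)Nc2cc3c(Nc4ccc(F)c(Cl)c4)ncnc3cc2OC)c(O)c1` changes the 2,4-dihydroxyphenyl of compound 2 to 4-(diethylamino)-2-hydroxyphenyl, with diethylamino in place of hydroxy on an aromatic carbon. Among the measured compounds shown here, the only measured step bearing on this is a 1.3-fold higher number from compound 1 to compound 2 (0.13 log units; within the scatter), which exchanged 3-bromophenyl for 2,4-dihydroxyphenyl and stayed within the scatter. It offers slim evidence, and it gives no firm direction, so no clear shift is expected in this assay. The expected change is a 1.3-fold lower number from compound 2 to compound 3 (0.13 log units; within the scatter). For compound 3 the estimate is 27000 nM, with an expected range from 10000 nM to 65000 nM.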

Compound 3, half-maximal inhibitory concentration: 27300 nM
The estimate for compound 3 lay 1.0-fold (0.00 log units) below the measured number, and the stated range covers the measured number.
By their numbers in this assay, from the lowest: compounds 1, 3 and 2 (each within the scatter of the next).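

In this assay, diethylamino in place of hydroxy on an aromatic carbon gives a 1.3-fold lower number from compound 2 to compound 3 (0.12 log units; within the scatter) and so stays level with compound 2, which shows that this position, meta to a hydroxy group, accepts five heavy atoms instead of one and no hydrogen-bond donor without a change beyond the scatter. Set against the 3-bromophenyl of compound 1, the 4-(diethylamino)-2-hydroxyphenyl group gives a 1.0-fold higher number from compound 1 to compound 3 (0.00 log units; within the scatter) as well, so compounds 1, 2 and 3 cannot be separated in this assay. No evidence is available on why these numbers stay together.

From the compounds shown here alone, it remains open whether a carboxylic acid or a longer chain on the amine nitrogen at this position would move the number beyond the scatter. Also open, going by these compounds, is whether methoxy in place of the remaining hydroxy would do so.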